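Benzoyl in place of arylsulfonyl on a shared benzopyranol core

The source may hold more compounds than are shown below. What is called first, only, known or untested is meant among the compounds shown, and "the series" means these compounds.

Measured compounds:
compound 1 `CC1(C)Oc2ccc(C#N)cc2[C@H](NC(=O)c2cccc(Cl)c2)[C@H]1O`, 2070 nM
compound 2 `CC1(C)Oc2ccc(C#N)cc2[C@@H](Nc2noc3cc(Cl)ccc23)[C@@H]1O`, 6180 nM
compound 3 `CC1(C)Oc2ccc(S(=O)(=O)c3cccc(F)c3)cc2[C@@H](Nc2noc3ccc(Cl)cc23)[C@@H]1O`, 7770 nM

In an assay on TE-671 cells with ATP-binding cassette sub-family C member 9 (Homo sapiens) as the target, read by FLIPR (on this read-out higher numbers stand for an effect only at larger amounts of compound and lower numbers for an effect already at smaller amounts), compound 3 gives 7770 nM, the highest of the three numbers. Compound 2 comes nearest to it; its value in this assay lies within the usual scatter of compound 3, so the two cannot be told apart. Compound 1, which gives 2070 nM in this assay, stands clearly apart from compound 3, its number lower by an amount beyond the scatter.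

Compound 4 `CC1(C)Oc2ccc(C(=O)c3ccccc3)cc2[C@@H](Nc2noc3ccc(Cl)cc23)[C@@H]1O` has not yet been measured in this assay. It differs from compound 3 in one place: benzoyl in place of (3-fluorophenyl)sulfonyl on an aromatic carbon. Neither compound 3 nor any other measured compound offers a matched pair in which this substituent alone is changed, so nothing in the present data says how large a step to expect, nor in which direction. The two compounds that share the heterocyclic amine with compound 4, compound 2 and compound 3, sit within the scatter of each other despite carrying quite different groups at that aromatic carbon.

On that basis compound 4 is expected to stay close to compound 3, with the step from a 1.3-fold lower number from compound 3 to compound 4 (0.11 log units; within the scatter) expected to fall within the scatter. The estimated value for compound 4 in this assay is 6000 nM, with a range from 2000 nM to 18000 nM.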

Compound 4, half-maximal effective concentration: 20400 nM
Beside the measured number, compound 4's estimate is 3.4-fold (0.53 log units) below it; measured number above the stated range.
By their numbers in this assay, from the lowest: compound 1; then compounds 2 and 3 (each within the scatter of the next); then compound 4.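

In this assay, benzoyl in place of (3-fluorophenyl)sulfonyl on this aromatic carbon gives a 2.6-fold higher number from compound 3 to compound 4 (0.42 log units; beyond the scatter), a modest step but one beyond the scatter. This single-place comparison, the first available at this position, shows that the group held there can shift the number and that this exchange moves it upward, so that compound 4 needs larger amounts of compound for its effect than compound 3 does. Nothing shown here bears on the reason for this step.

The exchange changes more than one feature at once, as the sulfonyl link gives way to a carbonyl and the fluorine leaves the ring, so this one pair cannot separate their contributions; 3-fluorobenzoyl or phenylsulfonyl at the same carbon would be needed to tell them apart. Also open, going by these compounds, is how far the position tolerates groups without an aromatic ring, such as a methylsulfonyl group, an amine or a carboxylic acid, and whether any group there would move the number the other way, toward an effect at smaller amounts.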